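The compounds below may be only part of what the source reports. "The series", "measured", "known", "first", "only" and "open" are said of these compounds alone.

Among the compounds with values here, compound 3 `CSc1nnc(Cc2ccc(Cl)cc2Oc2ccccc2Cl)[nH]1` gives 170% in a functional assay on the whole organism (strain NMRI) with Mus musculus as the target, with a stated time of 60 min, at a dose of 20 mg/kg by the intraperitoneal route (on this read-out higher numbers stand for a stronger effect at the one dose given and lower numbers for a weaker effect), the largest of the three numbers measured so far. Compound 2 `CCSc1nnc(Cc2ccccc2Oc2ccccc2)[nH]1` gives 169%, a number within the usual scatter of that of compound 3, so the two cannot be told apart. Compound 1 `S=c1[nH]nc(Cc2ccc(Cl)cc2Oc2ccccc2Cl)[nH]1` gives 159%, and the step of a number 11 percentage points higher from compound 1 to compound 3 (beyond the scatter) is the only one beyond the scatter; it puts a group of 7 heavy atoms in place of a group of 6 heavy atoms on a saturated chain carbon bound to an aromatic carbon. Compound 4 `CCCSc1nnc(Cc2ccc(Cl)cc2Oc2ccccc2Cl)[nH]1` differs from compound 3 by ethyl in place of hydrogen on a saturated chain carbon bound to a sulfur. Within the data shown here, no measured step makes this change on its own: compound 2 differs from compound 3 in more than one place, so its value shows only that a different chain at the sulfur can sit at a similar level, and the one step that touched this region, from compound 1 to compound 3, was modest. Compound 4 is therefore expected to stay close to compound 3, with an expected step of a number 5 percentage points lower from compound 3 to compound 4 (within the scatter) that lies within the scatter. The estimate for compound 4 is 165%, between 140% and 185%.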

Compound 4, a percentage reported as activity, at one dose (the size of the read-out at that dose, not a potency): 134%
Compound 4: the middle estimate sits 31 percentage points above what was measured; the measured number lies below the stated range.
By their numbers in this assay, from the lowest: compound 4; then compounds 1, 2 and 3 (each within the scatter of the next, the first and the last beyond it).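

In this assay, replacing methylsulfanyl with propylsulfanyl gives a number 36 percentage points lower from compound 3 to compound 4 (beyond the scatter), so the chain on the sulfur cannot be lengthened freely without changing the read-out. Within the data shown here, this single change is larger than the only earlier step in this set, a number 11 percentage points higher from compound 1 to compound 3 (beyond the scatter), and it shows that the similar value of compound 2 says nothing about chain length alone, as that compound differs from compound 3 in more than one place. Nothing measured on these compounds explains the fall.

From the compounds shown here alone, with only the methyl and propyl chains on this shared core, it remains open whether an ethyl chain on the sulfur would sit nearer compound 3 or compound 4, and whether a butyl chain would fall further. Going by these compounds, it is also open whether a chain ending in an amine or a carboxylic acid would behave like the propyl chain.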